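Methoxy for methyl on a second, fluorinated core

The source may hold more compounds than are shown below. What is called first, only, known or untested is meant among the compounds shown, and "the series" means these compounds.

Of the compounds shown here, three have been measured in a functional assay on A-431 cells (Homo sapiens) for antiproliferative activity, read by MTT assay; a higher number here means a weaker inhibitor, a lower number a stronger inhibitor. Compound 1 `Cc1ccc(C(=O)C(=C2NCCN2)c2c(Cl)c(Cl)c(C#N)c(Cl)c2C#N)cc1` gives 4.1 ug/mL in this assay. Compound 3 `COc1ccc(C(=O)C(=C2NCCN2)c2c(Cl)c(Cl)c(C#N)c(Cl)c2C#N)cc1` differs from it by methoxy in place of methyl on an aromatic carbon, and in this assay compound 3 gives 0.5 ug/mL. That single change made a step of an 8.2-fold lower number from compound 1 to compound 3 (0.91 log units; beyond the scatter). Compound 2 `Cc1ccc(C(=O)C(=C2NCCN2)c2c(Cl)c(F)c(C#N)c(F)c2C#N)cc1` has a different core; how the two cores differ is not broken down here. In this assay compound 2 gives 1.7 ug/mL, a number between those of compound 1 and compound 3.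

Compound 4 `COc1ccc(C(=O)C(=C2NCCN2)c2c(Cl)c(F)c(C#N)c(F)c2C#N)cc1` has not yet been measured. It differs from compound 2 by methoxy in place of methyl on an aromatic carbon, and the place of the change is described in the same words as for compound 1 and compound 3, so it is the same change on a second core. Among the compounds with values here, only one example of this change has been seen, so its size on the second core is uncertain. Still, because compound 1 to compound 3 moved by an 8.2-fold lower number from compound 1 to compound 3 (0.91 log units; beyond the scatter), a step of about a 6.8-fold lower number from compound 2 to compound 4 (0.83 log units; beyond the scatter) is expected from compound 2 to compound 4. Compound 4 is therefore expected to give about 0.25 ug/mL in this assay, most likely between 0.08 ug/mL and 0.8 ug/mL.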

Compound 4, half-maximal inhibitory concentration: 0.7 ug/mL
Compound 4: middle estimate off by 2.8-fold (0.45 log units), on the low side; measured number inside the range.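

In this assay, methoxy in place of methyl lowered the number again on the second core, with a step of a 2.4-fold lower number from compound 2 to compound 4 (0.39 log units; beyond the scatter). Within the data shown here, the direction of the change therefore carried over from one core to the other, but its size did not, as the two steps show when set side by side: the same change on two cores in this assay, an 8.2-fold lower number (0.91 log units; beyond the scatter) from compound 1 to compound 3 and a 2.4-fold lower number (0.39 log units; beyond the scatter) from compound 2 to compound 4, 3.4-fold (0.53 log units) apart, beyond the scatter of two such steps With only two cores, this is a single comparison: it shows that the size of the step can depend on the core it is made on, but it does not explain why the step differs, and it gives no rule for predicting the step on a third core.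

The compounds shown leave open how other groups at the same place on the phenyl ring, such as an ethoxy group, a hydroxyl group, a chlorine atom or an amine, would compare with methyl and methoxy. They also leave open whether the smaller step on the second core would persist for any of these other groups.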